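A few compounds are considered here, and "the series" means these few. Any claim that something is new, unique, unknown or untested is made for them only; others in the source may bear on it.

Measured so far in a functional assay on L1210 cells (Mus musculus) for inhibition, read by MTT assay, with a stated time of 72 h; on this read-out lower numbers stand for stronger inhibition and higher numbers for weaker inhibition 
- compound 1 `COc1cc(NC(C)CCCNC(=O)Nc2cccc(F)c2)c2ncccc2c1` gives 19000 nM 
- compound 2 `COc1cc(NC(C)CCCNC(=O)Nc2cccc(C(F)(F)F)c2)c2ncccc2c1` gives 9200 nM 
- compound 3 `COc1cc(NC(C)CCCNC(=O)NNC(=O)Nc2cccc(C(F)(F)F)c2)c2ncccc2c1` gives 4000 nM 

Compound 3 holds the lowest of these three numbers, and its gaps to compound 2 and compound 1 both lie beyond the scatter. Compound 4 `COc1cc(NC(C)CCCNC(=O)NNC(=O)Nc2cccc(Cl)c2)c2ncccc2c1` differs from compound 3 in one place: chloro in place of trifluoromethyl on an aromatic carbon and nowhere else. Going by the values given here, no measured compound carries chloro. Among the compounds with values here, the only measured step touching this position is a 2.1-fold lower number from compound 1 to compound 2 (0.31 log units; beyond the scatter) for trifluoromethyl in place of fluoro, a modest step just beyond the scatter. It comes from compounds with a shorter chain than compound 3, so it is only a rough guide. A small rise in this assay is therefore expected, perhaps none beyond the scatter. The expected change is a 1.4-fold higher number from compound 3 to compound 4 (0.14 log units; within the scatter) and no more than a small one. The estimate for compound 4 is 5500 nM with an expected range from 2500 nM to 11000 nM in this read-out.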

Compound 4, half-maximal inhibitory concentration: 27000 nM
Compound 4: the middle estimate sits 4.9-fold (0.69 log units) below what was measured, and the stated range ends below it.
By their numbers in this assay, from the lowest: compound 3; then compound 2; then compounds 1 and 4 (each within the scatter of the next).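

In this assay, the group on the aromatic ring proves to matter strongly on the longer chain, with a 6.8-fold higher number from compound 3 to compound 4 (0.83 log units; beyond the scatter) for chloro in place of trifluoromethyl. The other two steps, a 2.9-fold higher number from compound 2 to compound 4 (0.47 log units; beyond the scatter) and a 1.4-fold higher number from compound 1 to compound 4 (0.15 log units; within the scatter), show that the longer chain ending in chloro does not stand below either shorter compound. Nothing measured here explains the size of this swap. Still open, on these data alone, is whether trifluoromethyl is uniquely suited to this position, or whether a nitrile or a carboxylic acid on the same aromatic carbon would give a similarly low number.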